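Compound 3: a cyano swap on compound 2

This account rests on a few compounds, and the source may have more. Where it says the series, first, only, none or still open, it means among the compounds named here.

- Compound 1 `COc1cc(/C=C2\CN(S(=O)(=O)c3ccc(F)cc3)C/C(=C\c3ccc(C#N)cc3)C2=O)cc(OC)c1OC` gives 12900 nM
- Compound 2 `COc1cc(/C=C2\CN(S(=O)(=O)c3ccc(NC(C)=O)cc3)C/C(=C\c3ccccc3F)C2=O)cc(OC)c1OC` gives 14000 nM

In an ADME assay on L02 cells (Homo sapiens) for cytotoxicity, read by MTT assay, with a stated time of 24 h (a lower number here means a stronger inhibitor, a higher number a weaker inhibitor), compound 2 gives 14000 nM and cannot be told apart from compound 1, which gives 12900 nM, since the two values lie within the scatter of each other. Compound 3 `COc1cc(/C=C2\CN(S(=O)(=O)c3ccc(NC(C)=O)cc3)C/C(=C\c3ccc(C#N)cc3)C2=O)cc(OC)c1OC` has not yet been measured. It differs from compound 2 by carrying 4-cyanophenyl in place of 2-fluorophenyl on a double-bonded chain carbon bound to a double-bonded ring carbon. Among the compounds with values here, no measured pair of compounds differing in one place is available to size such a change, so no step beyond the scatter is expected in this assay, and neither direction is favoured. The expected step of a 1.0-fold lower number from compound 2 to compound 3 (0.02 log units; within the scatter) is an estimate only. For compound 3 the estimated value is 13500 nM, with an expected range from 6500 nM to 28000 nM.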

Compound 3, half-maximal inhibitory concentration: 13600 nM
Estimate against measurement, compound 3: 1.0-fold (0.00 log units) below; the range from low to high includes it.
By their numbers in this assay, from the lowest: compounds 1, 3 and 2 (each within the scatter of the next).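

In this assay the place on a double-bonded chain carbon bound to a double-bonded ring carbon now has its first measured pair: 4-cyanophenyl in place of 2-fluorophenyl gives a step within the scatter (a 1.0-fold lower number from compound 2 to compound 3 (0.01 log units; within the scatter)), so compound 2 and compound 3 cannot be told apart. Acetamido in place of fluoro on an aromatic carbon likewise gives a step within the scatter (a 1.1-fold higher number from compound 1 to compound 3 (0.02 log units; within the scatter)), so that swap, too, shows no readable difference. Nothing measured here offers an explanation for either result.

The compounds shown leave open whether an aminophenyl or a carboxyphenyl group in place of 4-cyanophenyl would give a step beyond the scatter. They also leave open whether a carboxylic acid in place of acetamido would do so.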